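Closing a diol into a three-membered ring on the side chain

A few compounds are considered here, and "the series" means these few. Any claim that something is new, unique, unknown or untested is made for them only; others in the source may bear on it.

Of the compounds shown here, three that share one core have been tested in a functional assay on cells (Panel NCI-60 (60 carcinoma cell lines), Homo sapiens) for inhibition (a higher number here means a weaker inhibitor, a lower number a stronger inhibitor), and all three sit at the same level. Compound 1 `C[C@H]1C[C@@H](O)[C@@]23C1=C[C@@]1(C)CC[C@](C)(C[C@H](O)[C@H](O)[C@@](C)(O)CO)[C@H]1[C@@H]2CC[C@@H]3C` gives 18000 nM in this assay. Compound 2 `C[C@H]1CC[C@@]23C1=C[C@@]1(C)CC[C@](C)(C[C@H](O)[C@H](O)[C@@](C)(O)CO)[C@H]1[C@@H]2CC[C@@H]3C` gives 18000 nM in this assay, and the step of no change at the digits printed from compound 1 to compound 2 (within the scatter) shows this. Compound 3 `C[C@H]1CC[C@@]23C1=C[C@@]1(C)CC[C@](C)(C[C@H](O)C(=O)[C@@](C)(O)CO)[C@H]1[C@@H]2CC[C@@H]3C` gives 18000 nM in this assay; the step of no change at the digits printed from compound 2 to compound 3 (within the scatter) is again flat. Among the measured compounds shown here, compound 3 therefore stands level with compounds 1 and 2, with no measured step among the three reaching beyond the scatter.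

Compound 4 `C[C@H]1CC[C@@]23C1=C[C@@]1(C)CC[C@](C)(C[C@H](O)[C@H](O)C4(C)CO4)[C@H]1[C@@H]2CC[C@@H]3C` has not yet been measured. The change from compound 3 is a group of 6 heavy atoms (4 carbon, 2 oxygen; one three-membered non-aromatic ring with 1 hetero atom) in place of a group of 7 heavy atoms (4 carbon, 3 oxygen; no ring), on a saturated chain carbon bound to an oxygen on a saturated carbon and a saturated chain carbon. Neither of the measured steps involves a three-membered ring, so they bear on this change only loosely; both were flat, which suggests that alterations on this side chain have so far left the read-out untouched. The step from compound 3 to compound 4 is therefore expected to be no change at the digits printed from compound 3 to compound 4 (within the scatter), with no direction beyond the scatter. Compound 4 is estimated at 18000 nM, within a range of 6000 nM to 50000 nM.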

Compound 4, half-maximal inhibitory concentration: 18000 nM
The estimate for compound 4 equals the measured number at the digits printed; the measured number falls inside the stated range.
By their numbers in this assay, from the lowest: compounds 1, 2, 3 and 4 (each within the scatter of the next).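

Putting 2-methyloxiran-2-yl in place of 1-hydroxy-1-(hydroxymethyl)ethyl gives no change at the digits printed from compound 2 to compound 4 (within the scatter) in this assay, so a three-membered ring carrying an oxygen can stand at the end of this side chain with no measurable effect on the read-out. The comparison with the carbonyl-bearing side chain reads the same, with no change at the digits printed from compound 3 to compound 4 (within the scatter), which shows that the read-out at this place holds level even when the group that enters has a ring and fewer hydrogen-bond donors and acceptors than the one that leaves. Nothing available offers an explanation for this flat result.

On these data alone, with all four compounds level, it remains open whether any group at this place can move the read-out at all. An amine, a carboxylic acid or a longer chain here would be a sharper test of that.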